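Cytotoxicity of a Cyanophenyl Replacement for Fluorophenyl

The source may hold more compounds than are shown below. What is called first, only, known or untested is meant among the compounds shown, and "the series" means these compounds.

Among the measured compounds shown here, compound 1 `N#Cc1ccc(Nc2nccc(OCc3cccc(F)c3)n2)cc1` is one of only two compounds measured in an ADME assay on MT4 cells (Homo sapiens) for cytotoxicity, read by MTT assay, with a stated time of 5 days (a lower number here means that less compound is tolerated, a higher number that more compound is tolerated), where compound 1 gives 105000 nM. Compound 2 `N#Cc1ccc(Nc2nccc(OCc3cccc(C(F)(F)F)c3)n2)cc1` gives 118000 nM in this assay, and the two numbers sit within the scatter of each other, as the step of a 1.1-fold higher number from compound 1 to compound 2 (0.05 log units; within the scatter) shows. Compound 3 `N#Cc1ccc(Nc2nccc(OCc3ccccc3C#N)n2)cc1` differs from compound 1 by 2-cyanophenyl in place of 3-fluorophenyl on a saturated chain carbon bound to an oxygen on an aromatic ring. For the measured compounds named here, the single measured step is the only one bearing on this change, and it stayed within the scatter, so no movement beyond the scatter is expected. Compound 3 is therefore estimated to give 110000 nM (range 50000 nM to 250000 nM), an expected step of a 1.0-fold higher number from compound 1 to compound 3 (0.02 log units; within the scatter).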

Compound 3, half-maximal cytotoxic concentration: 113000 nM
Estimate against measurement, compound 3: 1.0-fold (0.01 log units) below; the measured number falls inside the stated range.
By their numbers in this assay, from the lowest: compounds 1, 3 and 2 (each within the scatter of the next).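

In this assay the entry of 2-cyanophenyl for 3-fluorophenyl brings a 1.1-fold higher number from compound 1 to compound 3 (0.03 log units; within the scatter) and so shows that this place on the saturated chain carbon also accepts a nitrile, with its hydrogen-bond acceptor, without a change beyond the scatter. Until now only fluoro and trifluoromethyl had been compared here, and this replacement differs in the ring's substituent and in its heavy-atom count. No supporting data explain why the numbers stay together. As far as these compounds go, whether an amine or a carboxylic acid on this ring would leave the number unchanged remains open, as does the effect of a longer chain in place of the saturated chain carbon.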